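Swapping nitro for bromo in a cytotoxic series

This account rests on a few compounds, and the source may have more. Where it says the series, first, only, none or still open, it means among the compounds named here.

Measured in a functional assay on KG-1a cells (Homo sapiens) for cytotoxicity, with a stated time of 24 h; a higher number here means a weaker inhibitor, a lower number a stronger inhibitor:
compound 1 `Nn1c(SCc2ccccc2[N+](=O)[O-])nnc1-c1c[nH]c2ccccc12`: 20800 nM
compound 2 `Nn1c(SCc2cccc([N+](=O)[O-])c2)nnc1-c1c[nH]c2ccccc12`: 650 nM
compound 3 `Nn1c(SCc2ccc([N+](=O)[O-])cc2)nnc1-c1c[nH]c2ccccc12`: 6900 nM

All three compounds carry a nitro group on the same shared framework and differ only in where that group sits. Compound 3, at 6900 nM, stands in the middle of the three. Compound 1 gives a higher number and compound 2 a lower one, and both gaps to compound 3 lie beyond the scatter.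

The next compound, compound 4 `Nn1c(SCc2ccc(Br)cc2)nnc1-c1c[nH]c2ccccc12`, keeps the framework but carries bromo in place of nitro on an aromatic carbon, para to a large group: bromo in place of nitro on an aromatic carbon. Going by the values given here, no measured pair in this set shows one group exchanged for another, so the size of this step rests on thin evidence. The expectation is a small step, perhaps towards a slightly lower number, and none clearly beyond the scatter. The estimated change is a 1.7-fold lower number from compound 3 to compound 4 (0.24 log units; within the scatter). The range stays wide, as moving the nitro group alone spans compound 2 at 650 nM and compound 1 at 20800 nM. For compound 4 the estimated value is 4000 nM, with an expected range from 1000 nM to 15000 nM.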

Compound 4, half-maximal inhibitory concentration: 55800 nM
Compound 4: middle estimate off by 14-fold (1.14 log units), on the low side, outside the stated range (above it).
By their numbers in this assay, from the lowest: compound 2; then compound 3; then compound 1; then compound 4.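

Going by these compounds alone, measured in this assay the exchange of nitro for bromo on an aromatic carbon, para to a large group, is the first step in the set that swaps one group for another, and it proves large (an 8.1-fold higher number from compound 3 to compound 4 (0.91 log units; beyond the scatter)) and beyond the scatter. Within the data shown here, the earlier compounds showed only that moving the nitro group around the ring changes the number, whereas this step shows that the identity of the group at this place matters too, since bromo here gives a clearly weaker inhibitor than nitro. No measurement available here explains the rise, so it cannot be said whether it comes from losing the nitro group or from bringing in bromo.

From the compounds shown here alone, it remains open whether the rise is particular to bromo or would follow with other groups at this place, such as an amine, a nitrile or a methoxy group. Going by these compounds, it is also open whether bromo, moved to the other places on the ring, would follow the order that the nitro compounds show.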